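The source may hold more compounds than are shown below. What is called first, only, known or untested is meant among the compounds shown, and "the series" means these compounds.

Series around the shared core of compound 1 `CN(C)CCn1cnnc1-c1cc(Oc2ccc(NC(=O)N/N=C/c3c(Cl)cccc3Cl)cc2F)ccn1`, the variation sitting on the carbon with a double bond to nitrogen. In a functional assay on U-87MG ATCC cells (Homo sapiens) for cytotoxicity, read by MTT assay, with a stated time of 72 h (on this read-out lower numbers stand for stronger inhibition and higher numbers for weaker inhibition), compound 1 gives > 100000 nM, which is a limit of the assay (the limit of > 100000 nM in this assay, at which 1 of the 3 values shown sits). Compound 2 `COc1ccc(/C=N/NC(=O)Nc2ccc(Oc3ccnc(-c4nncn4CCN(C)C)c3)c(F)c2)c(OC)c1OC` gives 7650 nM in this assay. Compound 3 `CN(C)CCn1cnnc1-c1cc(Oc2ccc(NC(=O)N/N=C/c3cccc(Br)c3)cc2F)ccn1` gives 830 nM in this assay, the lowest of the two numbers obtained; the step of a 9.2-fold lower number from compound 2 to compound 3 (0.96 log units; beyond the scatter) sets it clear of compound 2, and the steps of an at least 13-fold lower number from compound 1 to compound 2 (1.11 log units; beyond the scatter) and an at least 120-fold lower number from compound 1 to compound 3 (2.08 log units; beyond the scatter) show how strongly this aryl group moves the read-out. Compound 4 `CN(C)CCn1cnnc1-c1cc(Oc2ccc(NC(=O)N/N=C/c3ccc(O)cc3)cc2F)ccn1` carries the change (4-hydroxyphenyl in place of 3-bromophenyl on a carbon with a double bond to nitrogen). For the measured compounds named here, no measured step matches this swap; the recorded aryl changes ran from modest to large, so a step toward higher numbers beyond the scatter is expected, estimated as a 6.0-fold higher number from compound 3 to compound 4 (0.78 log units; beyond the scatter). Compound 4 is expected to give about 5000 nM in this assay, within 1000 nM to 40000 nM.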

Compound 4, half-maximal inhibitory concentration: 7750 nM
Compound 4: the middle estimate sits 1.6-fold (0.19 log units) below what was measured; the range from low to high includes it.
By their numbers in this assay, from the lowest: compound 3; then compounds 2 and 4 (each within the scatter of the next). At a limit, above all of these: compound 1.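

Replacing 3-bromophenyl with 4-hydroxyphenyl at this position gives a 9.3-fold higher number from compound 3 to compound 4 (0.97 log units; beyond the scatter), so the low number of compound 3 does not carry over to this aryl group. Two differently substituted aryl groups are not separated here: a 1.0-fold higher number from compound 2 to compound 4 (0.01 log units; within the scatter). Compound 4 still shows an at least 12-fold lower number from compound 1 to compound 4 (1.11 log units; beyond the scatter), a step read against a limit of the assay for compound 1: the limit of > 100000 nM in this assay, at which 1 of the 4 values shown sits.

Open, as far as these compounds go, is whether 3-hydroxyphenyl or 4-bromophenyl would separate the effect of the substituent from that of its place on the ring. Also open, from the compounds shown here alone, is whether an aminophenyl or carboxyphenyl group here would track compound 3 or compound 4.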